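A few compounds are considered here, and "the series" means these few. Any claim that something is new, unique, unknown or untested is made for them only; others in the source may bear on it.

In an assay for inhibition of MAP kinase-interacting serine/threonine-protein kinase 1 (Homo sapiens), read by luminescence and ADP-Glo, with a stated time of 2 h (on this read-out lower numbers stand for stronger inhibition and higher numbers for weaker inhibition), compound 3 `O=c1ccc(-c2ccc3cn[nH]c3c2)cn1Cc1cccc(Cl)c1` gives 37 nM, the second highest of the three numbers measured. Its nearest neighbour is compound 2 `Nc1n[nH]c2cc(-c3ccc(=O)n(Cc4cccc(Cl)c4)c3)ccc12`, which gives 11 nM; the step of a 3.4-fold higher number from compound 2 to compound 3 (0.53 log units; beyond the scatter) comes from a hydrogen in place of an amino group on an aromatic carbon. Furthest away is compound 1 `NC(=O)c1cccc(Cn2cc(-c3ccc4cn[nH]c4c3)ccc2=O)c1`, which gives 388 nM; the step of a 10-fold lower number from compound 1 to compound 3 (1.02 log units; beyond the scatter) comes from a chloro in place of a carbamoyl group on an aromatic carbon. Compound 4 `Cn1cc(-c2ccc3cn[nH]c3c2)ccc1=O` differs from compound 3 by hydrogen in place of 3-chlorophenyl on a saturated chain carbon bound to an aromatic nitrogen, so the whole 3-chlorobenzyl group shrinks to a methyl. The step from compound 1 to compound 3 bears most directly on this: it shows that merely swapping one group on that ring already moved this assay by a large amount. The step from compound 2 to compound 3 touches a different part of the molecule and says little here. Removing the ring altogether is expected to cost more than changing one group on it, so compound 4 is expected to give 600 nM, with a likely range from 150 nM to 3000 nM. That estimate means an expected step of a 16-fold higher number from compound 3 to compound 4 (1.21 log units; beyond the scatter), well beyond the scatter.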

Compound 4, half-maximal inhibitory concentration: > 2000 nM
Compound 4 was reported as a limit; the forecaster's own chance of this, stated with the estimate: 10%; middle value at least 3.3-fold (0.52 log units) from the limit.
By their numbers in this assay, from the lowest: compound 2; then compound 3; then compound 1. At a limit, above all of these: compound 4.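

Replacing the 3-chlorophenyl with hydrogen, which shrinks the 3-chlorobenzyl group to a methyl, gives an at least 54-fold higher number from compound 3 to compound 4 (1.73 log units; beyond the scatter) in this assay. Compound 4 is reported only as a limit, so this step has a floor but no known size: the limit of > 2000 nM in this assay, at which 1 of the 4 values shown sits.

The earlier step, a 10-fold lower number from compound 1 to compound 3 (1.02 log units; beyond the scatter), swapped one group on the ring and kept the ring itself, whereas this one shows that a methyl on the aromatic nitrogen does not keep the inhibition seen with 3-chlorobenzyl.

Still open, on these data alone, is whether the aromatic ring itself matters or whether something larger than methyl would do, a question that a plain benzyl, a propyl chain or a cyclohexylmethyl group in this place could address. As far as these compounds go, it is also open whether the amino group of compound 2 would change the picture on a methyl compound.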